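Ethyl on the aromatic nitrogen: compound 3 to compound 4

This account rests on a few compounds, and the source may have more. Where it says the series, first, only, none or still open, it means among the compounds named here.

Measured so far in an ADME assay on MDBK cells (Bos taurus) for cytotoxicity (a higher number here means that more compound is tolerated, a lower number that less compound is tolerated), each value a limit and not a number:
- compound 1 `Brc1ccccc1Cn1ccc2nc(-c3ccccc3)nc-2c1` gives > 100000 nM as its limit
- compound 2 `c1ccc(CCCn2ccc3nc(-c4ccccc4)nc-3c2)cc1` gives > 100000 nM as its limit
- compound 3 `c1ccc(-c2nc3cc[nH]cc-3n2)cc1` gives > 100000 nM as its limit

Compound 3 has no number, only a limit. The set sits together, with the limit of > 100000 nM in this assay, at which 3 of the 3 values shown sit, as the whole picture so far.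

The next compound is compound 4 `CCn1ccc2nc(-c3ccccc3)nc-2c1`, reached from compound 3 through (ethyl in place of hydrogen on an aromatic nitrogen), that is, ethyl in place of hydrogen on an aromatic nitrogen.

Among the compounds with values here, the one measured step that bears on this is a step that the two limits leave unreadable from compound 1 to compound 2, so it offers no size to carry over. Within the data shown here, compound 1 and compound 2 carry a chain on an aromatic nitrogen of the shared core where compound 3 has hydrogen, yet no measured compound has come off the limit. No step beyond the scatter is expected in this assay, in either direction.

The expected change is a number no higher from compound 3 to compound 4 (the limit leaves the size open), given that the reference is itself a limit. For compound 4 the estimated value is 100000 nM, with an expected range from 40000 nM to 200000 nM, and a report as a limit is the likely outcome.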

Compound 4, half-maximal cytotoxic concentration: > 100000 nM
Compound 4: no number, only a limit; the forecaster's own chance of this, stated with the estimate: 85%; the middle value lies on the limit itself.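

In this assay compound 4 gives > 100000 nM, a limit and not a number. Within the data shown here, no step among compound 1, compound 2, compound 3 and compound 4 can be read. The compounds shown leave open at what concentration any of them becomes cytotoxic, and whether the group on the aromatic nitrogen changes that.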